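Removing the Bromo Group from a Sulfonamide Side Chain

The compounds below may be only part of what the source reports. "The series", "measured", "known", "first", "only" and "open" are said of these compounds alone.

Of the compounds shown here, three built on one shared core have been tested in an assay on HEK293 cells for displacement of a labelled ligand from 5-hydroxytryptamine receptor 6 (Homo sapiens), with a stated time of 60 min, tested at 0.01 uM, in the presence of a further agent that is not named here; a lower number here means a weaker effect, a higher number a stronger effect of the compound at the concentration tested. Compound 1 `COc1cc(N)c(Cl)cc1C(=O)CCC1CCN(CCNS(=O)(=O)c2cc(Br)ccc2Br)CC1` gives 16% in this assay. Compound 2 `COc1cc(N)c(Cl)cc1C(=O)CCC1CCN(CCNS(=O)(=O)c2ccc3c(c2)NC(=O)CO3)CC1` is reported in this assay as "not active" (no number reported), with no number attached. Compound 3 `COc1ccc(S(=O)(=O)NCCN2CCC(CCC(=O)c3cc(Cl)c(N)cc3OC)CC2)cc1Br` is reported in this assay as "not active" (no number reported), again without a number. Compound 3 therefore stands with no single value of its own; it is one of two entries in this small set without a figure, and only compound 1 carries one.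

Compound 4 `COc1ccc(S(=O)(=O)NCCN2CCC(CCC(=O)c3cc(Cl)c(N)cc3OC)CC2)cc1` has not yet been measured. It differs from compound 3 in one place: hydrogen in place of bromo on an aromatic carbon. In what is counted the change is small, a single bromine atom leaving and a hydrogen entering on an aromatic carbon ortho to the methoxy group.

For the measured compounds named here, no measured pair in this set shows what such a change does. With compound 3 reported as "not active" (no number reported) and compound 1 at 16%, nothing points to a move beyond the scatter in this assay in either direction, and a low read-out, or again one without a number, seems the likeliest outcome. Compound 4 is accordingly expected to show 5% in this assay, within a range from -10% to 20%.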

Compound 4, a percentage reported as inhibition, at one concentration (the size of the read-out at that concentration, not a potency): 36%
Estimate against measurement, compound 4: 31 percentage points below; measured number outside the range, above it.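

In this assay the aromatic carbon ortho to a methoxy group proves not to be indifferent to what it carries: compound 3, with bromo there, is reported as "not active" (no number reported) and compound 4, with hydrogen there, gives 36% at the single concentration tested. Compound 3 has no number. For the compounds shown here, this pair yields no step that can be read, and the printed entries are all it offers. Going by these compounds alone, the 4-methoxyphenyl side chain can, however, be set against the 2,5-dibromophenyl side chain on the same sulfonyl sulfur, which gives a number 20 percentage points higher from compound 1 to compound 4 (beyond the scatter) and so provides the first comparison in this set that lies beyond the scatter. Nothing among the data bears on why removing the bromo group has this effect.

The compounds shown leave open whether a fluoro, chloro or methyl group on that same aromatic carbon would read like hydrogen or like bromo. They also leave open whether the result depends on the methoxy group, which a hydroxy group or a plain phenyl ring in the 4-methoxyphenyl side chain would test, and how compound 4 behaves at other concentrations.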